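Swapping a Hydroxyalkyl Chain for an Amide Group

The source may report more compounds than this note shows. Statements on the series, on what has been measured and on what is new or still open speak of the compounds shown alone.

Compound 1 `COc1ccc(C)c(N2CCC(COc3cccc(C(CC(=O)O)C4CC4)c3)CC2)c1`: 270 nM
Compound 2 `COc1ccc(C(C)C)c(N2CCC(COc3cccc(C(CC(=O)O)C4CC4)c3)CC2)c1`: 120 nM
Compound 3 `COc1ccc(CCC(C)(C)O)c(N2CCC(COc3cccc(C(CC(=O)O)C4CC4)c3)CC2)c1`: 970 nM

In a functional assay on cells for agonist activity at Free fatty acid receptor 1 (Homo sapiens), read by FLIPR and calcium flux, with a stated time of 60 min (on this read-out higher numbers stand for an effect only at larger amounts of compound and lower numbers for an effect already at smaller amounts), compound 3 stands at the highest number of the three. The step from compound 1 was a 3.6-fold higher number from compound 1 to compound 3 (0.56 log units; beyond the scatter), and that from compound 2 was an 8.1-fold higher number from compound 2 to compound 3 (0.91 log units; beyond the scatter), so the 3-hydroxy-3-methylbutyl chain went with weaker activity than either small alkyl group. Compound 4 `COc1ccc(C(=O)N(C)CC(C)(C)C)c(N2CCC(COc3cccc(C(CC(=O)O)C4CC4)c3)CC2)c1` makes a further change: methyl(neopentyl)carbamoyl in place of 3-hydroxy-3-methylbutyl on an aromatic carbon. Going by the values given here, no measured step covers an amide on this position, and the new group is larger than any tried here yet carries no hydrogen-bond donor. The two steps leading to compound 3 suggest that leaving this chain behind may bring the number back down, so for compound 4 a modest lowering is expected, a 2.4-fold lower number from compound 3 to compound 4 (0.38 log units; beyond the scatter), with an estimate of 400 nM and a range of 120 nM to 1500 nM.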

Compound 4, half-maximal effective concentration: 100 nM
Compound 4: the middle estimate sits 4.0-fold (0.60 log units) above what was measured; measured number outside the range, below it.
By their numbers in this assay, from the lowest: compounds 4 and 2 (each within the scatter of the next); then compound 1; then compound 3.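

The methyl(neopentyl)carbamoyl group gives a 9.7-fold lower number from compound 3 to compound 4 (0.99 log units; beyond the scatter) in this assay and also a 2.7-fold lower number from compound 1 to compound 4 (0.43 log units; beyond the scatter) on the same read-out, while a 1.2-fold lower number from compound 2 to compound 4 (0.08 log units; within the scatter) leaves it level with the isopropyl compound. This position therefore accepts a group larger than any of the earlier ones, and a large group here need not bring the weak number of compound 3. Nothing measured here explains the change.

On these data alone, whether the carbonyl or the neopentyl part matters more stays open. So does what an amide keeping the amide hydrogen, or a simple amine, would give at this position.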